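Carboxy to ethoxycarbonyl on the chain of compound 3

The source may hold more compounds than are shown below. What is called first, only, known or untested is meant among the compounds shown, and "the series" means these compounds.

Measured in a physicochemical assay for lipophilicity, measured as octanol-water partition, at pH 7.4; a lower number here means a more polar compound, a higher number a more lipophilic compound:
compound 1 `CC(=O)N[C@H](C(=O)N1C[C@H](O)C[C@H]1C(=O)N[C@@H](CCC(C)(C)C)c1ccc(-c2scnc2C)cc1)C(C)(C)C` 3.21
compound 2 `CC(=O)N[C@H](C(=O)N1C[C@H](O)C[C@H]1C(=O)N[C@@H](CCc1ccc(Br)cc1)c1ccc(-c2scnc2C)cc1)C(C)(C)C` 4.08
compound 3 `CC(=O)N[C@H](C(=O)N1C[C@H](O)C[C@H]1C(=O)N[C@@H](CCC(=O)O)c1ccc(-c2scnc2C)cc1)C(C)(C)C` -0.44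

Compound 3 has the lowest number of the three, and both other compounds lie beyond the scatter above it. Compound 4 `CCOC(=O)CC[C@H](NC(=O)[C@@H]1C[C@@H](O)CN1C(=O)[C@@H](NC(C)=O)C(C)(C)C)c1ccc(-c2scnc2C)cc1` differs from it in one place: ethyl in place of hydrogen on an oxygen next to a carbonyl group, or carboxy to ethoxycarbonyl.

Two measured steps bring in the free carboxy group at the same chain carbon, and both are large: a number 3.65 log units lower from compound 1 to compound 3 (beyond the scatter) and a number 4.52 log units lower from compound 2 to compound 3 (beyond the scatter). Between the two chain ends without carboxy, the step is only modest: a number 0.87 log units higher from compound 1 to compound 2 (beyond the scatter). Compound 4 no longer has the free carboxy group, so a large upward move in this assay is expected, recovering most of the drop seen in the step to compound 3. It is expected to end near compound 1 at 3.21. The expected change is a number 3.04 log units higher from compound 3 to compound 4 (beyond the scatter). The estimate for compound 4 is 2.6, with an expected range from 2 to 3.2.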

Compound 4, distribution coefficient: 1.59
Compound 4: the middle estimate sits 1.01 log units above what was measured; measured number below the stated range.
By their numbers in this assay, from the lowest: compound 3; then compound 4; then compound 1; then compound 2.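

In this assay, replacing carboxy with ethoxycarbonyl on this chain gives a large rise (a number 2.03 log units higher from compound 3 to compound 4 (beyond the scatter)), so the free carboxy group accounts for only part of the distance between compound 3 and the other chain ends. The ester does not reach either of them: both the step from the tert-butyl end (a number 1.62 log units lower from compound 1 to compound 4 (beyond the scatter)) and the step from the 4-bromophenyl end (a number 2.49 log units lower from compound 2 to compound 4 (beyond the scatter)) remain large and downward, leaving compound 4 in an intermediate place in the series. Nothing available accounts for this intermediate place.

The compounds shown leave open where a methyl ester, a primary amide or an amine on the same chain carbon would fall. They also leave open whether a longer alkyl ester would close the remaining gap to compound 1.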